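Replacing 1-methyl-1H-indol-2-yl with 6-methoxypyridin-3-yl

The compounds below may be only part of what the source reports. "The series", "measured", "known", "first", "only" and "open" are said of these compounds alone.

In an ADME assay on microsomes from liver (Rattus norvegicus) for metabolic stability, read by LC-MS, using NADPH, with stated times of 5 min and 60 min, tested at 4 uM (on this read-out lower numbers stand for a less stable compound and higher numbers for a more stable compound), compound 1 (`CC1=C(c2nc(-c3ccc(C#N)cc3)cs2)C(c2cc3ccccc3n2C)NC(=O)N1`) reaches 62.9% and so stands level, within the scatter, with compound 3 (`CC1=C(c2nc(-c3ccc(C#N)cc3)cs2)C(c2ccc(Cl)nc2)NC(=O)N1`) at 63.4% while compound 2 (`CC1=C(c2nc(-c3ccc(C#N)cc3)cs2)C(c2ccc(F)nc2)NC(=O)N1`) at 49.4% stands clearly lower. These three share one core and differ only in the group on a saturated ring carbon.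

Compound 4 (`COc1ccc(C2NC(=O)NC(C)=C2c2nc(-c3ccc(C#N)cc3)cs2)cn1`) has not been measured yet. Its difference from compound 1 is this: 6-methoxypyridin-3-yl in place of 1-methyl-1H-indol-2-yl on a saturated ring carbon and the rest of the structure stays the same.

The closest guides are the two steps that also remove 1-methyl-1H-indol-2-yl. The swap to 6-fluoropyridin-3-yl shows a number 13.5 percentage points lower from compound 1 to compound 2 (beyond the scatter) and is a modest drop. The swap to 6-chloropyridin-3-yl shows a number 0.5 percentage points higher from compound 1 to compound 3 (within the scatter) and leaves the number unchanged within the scatter. Chloro in place of fluoro shows a number 14 percentage points higher from compound 2 to compound 3 (beyond the scatter) so the outcome on this pyridine clearly depends on the single group it carries. For the measured compounds named here, no measured compound here carries methoxy, so these steps only bracket the answer, and a modest drop seems the likeliest result. The expected step is a number 10.9 percentage points lower from compound 1 to compound 4 (beyond the scatter) as an estimate with wide uncertainty. Going by the values given here, compound 4 is estimated to give 52% within a range of 36% to 68% when tested in this assay for the first time.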

Compound 4, percent of the compound remaining: 69.4%
Estimate against measurement, compound 4: 17.4 percentage points below, outside the stated range (above it).
By their numbers in this assay, from the lowest: compound 2; then compounds 1, 3 and 4 (each within the scatter of the next).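

In this assay, compound 4 shows that a pyridine carrying methoxy can stand level with the 1-methyl-1H-indol-2-yl group on this saturated ring carbon (a number 6.5 percentage points higher from compound 1 to compound 4 (within the scatter)). On the pyridine itself, methoxy and chloro cannot be told apart (a number 6 percentage points higher from compound 3 to compound 4 (within the scatter)), whereas methoxy and fluoro can (a number 20 percentage points higher from compound 2 to compound 4 (beyond the scatter)). Among the three pyridines, only compound 2, which carries fluoro, therefore stands apart from the other two, and nothing given here explains why this one group differs.

The pyridines shown each carry only a fluoro, chloro or methoxy group, so it remains open how an amine, a carboxylic acid or a longer chain such as butoxy would read in this assay on the same ring. Going by these compounds, it is also open whether a pyridin-3-yl group with no added group at all would stand with compound 2 or with compounds 3 and 4, which would show whether fluoro or the other two groups make the difference.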